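Cyano Substitution on Two Cores: Cytotoxicity Outlook

The source may hold more compounds than are shown below. What is called first, only, known or untested is meant among the compounds shown, and "the series" means these compounds.

Compound 1 `Cc1ccccc1-c1cnnc(NCc2cc(-c3ccccc3)[nH]n2)n1` and compound 3 `Cc1cc(C#N)ccc1-c1cnnc(NCc2cc(-c3ccccc3)[nH]n2)n1` share one core. Compound 3 differs from compound 1 by cyano in place of hydrogen on an aromatic carbon. Compound 2 `Cc1ccccc1-c1ccnc(NCc2cc(-c3ccccc3)[nH]n2)n1` rests on another core, and the difference between the two cores is not broken down here. Compound 4 `Cc1cc(C#N)ccc1-c1ccnc(NCc2cc(-c3ccccc3)[nH]n2)n1` differs from compound 2 by cyano in place of hydrogen on an aromatic carbon, the same change as that from compound 1 to compound 3, made at the same place.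

In an ADME assay on CEM174 cells (Homo sapiens) for cytotoxicity (on this read-out higher numbers stand for lower toxicity in this test and lower numbers for higher toxicity in this test), compound 1 gives > 10000 nM, which is a limit of the assay and not a number. In this assay compound 3 gives > 10000 nM, again a limit. In this assay compound 2 gives > 10000 nM, also a limit. The step that the two limits leave unreadable from compound 1 to compound 3 therefore cannot be sized, because the limit of > 10000 nM in this assay, at which 3 of the 3 values shown sit, holds every value shown.

Going by the values given here, the account of compound 4 rests on thin ground: the only measured instance of the change, from compound 1 to compound 3, leaves both ends at the limit, and compound 2 itself sits at the limit. The step from compound 2 to compound 4 in this assay is expected to be a step that the limit leaves unreadable from compound 2 to compound 4, meaning no readable change, because the limit of > 10000 nM in this assay, at which 3 of the 3 values shown sit, is where all three measured compounds stand. Compound 4 is accordingly estimated at 12000 nM in this assay, with an expected range from 6000 nM to 30000 nM, and most likely it will again be reported only as a limit.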

Compound 4, half-maximal cytotoxic concentration: > 10000 nM
Compound 4: only a limit was reported (the forecaster's own chance of this, stated with the estimate: 80%); the middle value is on the limit's open side.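

In this assay compound 4 gives > 10000 nM, which is a limit of the assay and not a number. No step can be read between compound 2 and compound 4, because both rest at the same limit: the limit of > 10000 nM in this assay, at which 4 of the 4 values shown sit.

The compounds shown leave open whether cyano in place of hydrogen on an aromatic carbon alters cytotoxicity on either core, and whether the two cores differ at all.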